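The compounds below may be only part of what the source reports. "The series", "measured", "known", "first", "only" and "open" are said of these compounds alone.

In a functional assay on cells (Homo sapiens) for cytotoxicity, read by MTT assay, with a stated time of 24 h (on this read-out higher numbers stand for weaker inhibition and lower numbers for stronger inhibition), compound 1 `CCCCCCCCCCCCCCNC(=O)[C@H](CO)/N=C/c1cccc(C)c1` gives 82900 nM and compound 3 `CCCCCCCCCCCCCCNC(=O)[C@H](CO)NCc1ccccc1OC` gives 100000 nM while compound 2 `CCCCCCCCCCCCCCNC(=O)[C@H](CO)/N=C/c1ccccc1O` gives 19000 nM as the lowest of the three numbers. The other two compounds both sit clearly away from it: the data show a 4.4-fold lower number from compound 1 to compound 2 (0.64 log units; beyond the scatter) and a 5.3-fold higher number from compound 2 to compound 3 (0.72 log units; beyond the scatter) as modest steps, whereas a 1.2-fold higher number from compound 1 to compound 3 (0.08 log units; within the scatter) stays inside the scatter. Compound 4 `CCCCCCCCCCCCCCNC(=O)[C@H](CO)/N=C/c1cccc(Cl)c1` has not yet been measured. It differs from compound 2 by 3-chlorophenyl in place of 2-hydroxyphenyl on a carbon with a double bond to nitrogen and so carries 3-chlorophenyl in place of 2-hydroxyphenyl on a carbon with a double bond to nitrogen. Among the compounds with values here, no measured compound carries chlorine, so the nearest guide is compound 1, which also lacks the 2-hydroxyphenyl: a 4.4-fold lower number from compound 1 to compound 2 (0.64 log units; beyond the scatter) is the step that bears most directly on this change. A step of about that size, running the other way, is therefore expected in this assay and the estimate is a 3.2-fold higher number from compound 2 to compound 4 (0.50 log units; beyond the scatter) as the expected move. Compound 4 is expected at 60000 nM with an estimated range from 25000 nM to 130000 nM on this read-out.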

Compound 4, half-maximal inhibitory concentration: 24100 nM
For compound 4 the middle estimate is 2.5-fold (0.40 log units) above the measured one; the measured number lies below the stated range.
By their numbers in this assay, from the lowest: compounds 2 and 4 (each within the scatter of the next); then compounds 1 and 3 (each within the scatter of the next).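

In this assay, 2-hydroxyphenyl proves not to be required for the low end of this small series: with 3-chlorophenyl on the carbon with a double bond to nitrogen, a 1.3-fold higher number from compound 2 to compound 4 (0.10 log units; within the scatter) stays within the scatter, although the entering group counts 0 hydrogen-bond donors and 0 hydrogen-bond acceptors. Chloro in place of methyl on an aromatic carbon gives a 3.4-fold lower number from compound 1 to compound 4 (0.54 log units; beyond the scatter), so the gap that first set compound 2 apart from compound 1 does not belong to 2-hydroxyphenyl alone. The step of a 4.1-fold lower number from compound 3 to compound 4 (0.62 log units; beyond the scatter) points the same way, but it changes a larger group and cannot be assigned to the aromatic substituent alone.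

Nothing given here explains these steps. Going by these compounds, whether an amine, a nitrile or a carboxylic acid on the same aromatic ring would stand with compound 2 and compound 4 or with compound 1 remains open.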